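Thiophene Returns in Place of Furan on the Amine Chain

A few compounds are considered here, and "the series" means these few. Any claim that something is new, unique, unknown or untested is made for them only; others in the source may bear on it.

Compound 1, `C[C@H]1[C@H](NCc2cc(Br)cs2)C[C@H]2C[C@@H]1C2(C)C`: 6250 nM
Compound 2, `C[C@H]1[C@H](NCc2ccoc2)C[C@H]2C[C@@H]1C2(C)C`: > 100000 nM (a limit of the assay, not a number)

Of the compounds shown here, two have so far been measured in an ADME assay on MDCK cells (Canis lupus familiaris) for cytotoxicity, read by microscopy, with a stated time of 48 h; on this read-out higher numbers stand for lower toxicity in this test and lower numbers for higher toxicity in this test. Compound 1 `C[C@H]1[C@H](NCc2cc(Br)cs2)C[C@H]2C[C@@H]1C2(C)C` gives 6250 nM. For compound 2 `C[C@H]1[C@H](NCc2ccoc2)C[C@H]2C[C@@H]1C2(C)C` the assay reports only a limit, > 100000 nM, which is the limit of > 100000 nM in this assay, at which 1 of the 2 values shown sits. Within the data shown here, the single measured step is an at least 16-fold higher number from compound 1 to compound 2 (1.20 log units; beyond the scatter), and compound 2 therefore stands at the upper edge of what has been measured, known only as a limit. Compound 3 `Cc1csc(CN[C@@H]2C[C@H]3C[C@@H]([C@H]2C)C3(C)C)c1` has not been measured; it differs from compound 2 by 4-methylthiophen-2-yl in place of furan-3-yl on a saturated chain carbon bound to an amine nitrogen. This change runs the measured step in reverse, with 4-methylthiophen-2-yl rather than 4-bromothiophen-2-yl now entering. Since the step from compound 1 to compound 2 was large, the return to a thiophene is expected to lower the number again, beyond the scatter. Compound 3 is expected to give 15000 nM (range 4000 nM to 100000 nM), which is the expected step of an at least 6.6-fold lower number from compound 2 to compound 3 (0.82 log units; beyond the scatter).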

Compound 3, minimum cytotoxic concentration: 12500 nM
Beside the measured number, compound 3's estimate is 1.2-fold (0.08 log units) above it, and the stated range covers the measured number.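

In this assay, 4-methylthiophen-2-yl in place of furan-3-yl on a saturated chain carbon bound to an amine nitrogen gives an at least 8.0-fold lower number from compound 2 to compound 3 (0.90 log units; beyond the scatter), so among these three compounds both thiophenes fall on the more toxic side of the furan. Methyl in place of bromo on an aromatic carbon gives a 2.0-fold higher number from compound 1 to compound 3 (0.30 log units; within the scatter), which shows that the bromo group is not needed for the low number seen with compound 1. Compound 2 is known only as a limit: the limit of > 100000 nM in this assay, at which 1 of the 3 values shown sits.

The compounds shown leave open whether the ring atom, the point of attachment or the ring substituent accounts for the gap, since these differ together between the furan and the thiophenes. They also leave open whether a plain phenyl ring or an unsubstituted thiophene would stand with the thiophenes or with the furan.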